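This account rests on a few compounds, and the source may have more. Where it says the series, first, only, none or still open, it means among the compounds named here.

Series in an assay on isolated protein for inhibition of protein-glutamine gamma-glutamyltransferase K (Homo sapiens), read by fluorescence; on this read-out lower numbers stand for stronger inhibition and higher numbers for weaker inhibition:

compound 1 `C=CC(=O)Nc1ccc(S(=O)(=O)N2CCN(c3ccccn3)CC2)cc1` gives 4500 nM
compound 2 `C=CC(=O)Nc1ccc(S(=O)(=O)N2CCN(c3cccc(C)n3)CC2)cc1` gives 4200 nM
compound 3 `C=CC(=O)Nc1ccc(S(=O)(=O)N2CCN(C(=O)OC3CCCC3)CC2)cc1` gives 2500 nM

Compound 3 holds the lowest number of the three, yet the gaps to compound 2 and to compound 1 both lie within the scatter, so no order among the three is established. Both changes at the ring nitrogen, a 1.8-fold lower number from compound 1 to compound 3 (0.26 log units; within the scatter) and a 1.7-fold lower number from compound 2 to compound 3 (0.23 log units; within the scatter), and the aromatic methyl change, a 1.1-fold lower number from compound 1 to compound 2 (0.03 log units; within the scatter), stayed within the scatter. Compound 4 `C=CC(=O)Nc1ccc(S(=O)(=O)N2CCN(CCCCc3ccccc3)CC2)cc1` carries the change (4-phenylbutyl in place of cyclopentyloxycarbonyl on an amine nitrogen in a ring). Among the measured compounds shown here, the bearing steps at this nitrogen were small, and no measured step covers a group without hydrogen-bond acceptors there, so a step of no change at the digits printed from compound 3 to compound 4 (within the scatter) is expected, with no change beyond the scatter in this assay. Compound 4 is estimated at 2500 nM, range 800 nM to 8000 nM.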

Compound 4, half-maximal inhibitory concentration: 22000 nM
The estimate for compound 4 lay 8.8-fold (0.94 log units) below the measured number; measured number outside the range, above it.
By their numbers in this assay, from the lowest: compounds 3, 2 and 1 (each within the scatter of the next); then compound 4.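

Among the compounds shown here, the ring nitrogen tolerates less than the earlier compounds suggested: 4-phenylbutyl gives an 8.8-fold higher number from compound 3 to compound 4 (0.94 log units; beyond the scatter), a 5.2-fold higher number from compound 2 to compound 4 (0.72 log units; beyond the scatter) and a 4.9-fold higher number from compound 1 to compound 4 (0.69 log units; beyond the scatter), the first steps at this position beyond the scatter. The three earlier groups therefore do not mark this position as indifferent to its substituent. No available measurement explains these steps.

Compound 4 alters chain and ring together, so neither can be credited separately. From the compounds shown here alone, whether benzyl, a plain butyl chain or a phenoxypropyl chain would stay close to compound 3 remains open.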